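From an Ethyl to a Methoxyphenyl Group on the Ring Amine

The source may report more compounds than this note shows. Statements on the series, on what has been measured and on what is new or still open speak of the compounds shown alone.

Compound 1, `CCN1CCN(CC(=O)Nc2nc3ccccc3[nH]2)CC1`: 35.7%
Compound 2, `O=C(CN1CCN(c2ccccc2)CC1)Nc1nc2ccccc2[nH]1`: 24.1%

Both measured compounds share the same core and differ only in the group carried on an amine nitrogen in a ring. In a functional assay, read by spectrophotometry, with a stated time of 30 min, tested at 50 ug/mL (on this read-out higher numbers stand for a stronger effect at the one concentration tested and lower numbers for a weaker effect), compound 1 gives 35.7%, the higher of the two numbers; compound 2 gives 24.1%, and the step of a number 11.6 percentage points lower from compound 1 to compound 2 (beyond the scatter) lies beyond the scatter.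

Compound 3, `COc1ccccc1N1CCN(CC(=O)Nc2nc3ccccc3[nH]2)CC1`, has not yet been measured. It differs from compound 1 in one place: 2-methoxyphenyl in place of ethyl on an amine nitrogen in a ring. The group that enters is again a six-membered aromatic ring, now carrying one oxygen as a hydrogen-bond acceptor, so the closest guide is the swap from ethyl to phenyl. Among the compounds with values here, that single relevant step was a modest drop, and a drop of similar size is expected here because a number 11.6 percentage points lower from compound 1 to compound 2 (beyond the scatter) is the only comparison available. Compound 3 is therefore expected to give about 23% in this assay, within 9% to 38%, which means an expected step of a number 12.7 percentage points lower from compound 1 to compound 3 (beyond the scatter).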

Compound 3, a percentage reported as activity, at one concentration (the size of the read-out at that concentration, not a potency): 35.7%
For compound 3 the middle estimate is 12.7 percentage points below the measured one; low and high end bracket the measured number.
By their numbers in this assay, from the lowest: compound 2; then compounds 1 and 3 (each within the scatter of the next).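

In this assay, putting 2-methoxyphenyl in place of ethyl on the amine nitrogen in the ring gives no change at the digits printed from compound 1 to compound 3 (within the scatter) and shows that a large aromatic group at this position need not lower the read-out, something compound 2 alone could not reveal. Placing methoxy in place of hydrogen on an aromatic carbon gives a number 11.6 percentage points higher from compound 2 to compound 3 (beyond the scatter) and shows that the lower number of compound 2 does not carry over to every aromatic group here, since this single change separates the two compounds. Nothing measured here explains how the methoxy group produces this difference.

On these data alone, it remains open whether another group on the same aromatic ring, such as a chlorine atom, a hydroxyl or a trifluoromethyl, would behave like methoxy, and whether a benzyl or a longer chain in place of ethyl on the ring nitrogen would keep the read-out at the level of compound 1. Each number also comes from one concentration, so these compounds give the size of the effect at that concentration and leave their potency unknown.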